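This account rests on a few compounds, and the source may have more. Where it says the series, first, only, none or still open, it means among the compounds named here.

In an assay on isolated protein for agonist activity at Bile acid receptor (Homo sapiens), read by AlphaScreen, with a stated time of 30 min (on this read-out higher numbers stand for larger maximal responses and lower numbers for smaller maximal responses), compound 1 `Cc1ccccc1-n1nc(C)c2c1NC(=O)[C@H](C)S[C@@H]2c1ccc(Oc2ccccc2)cc1` gives 118%, while compound 2 `Cc1nn(-c2ccccc2C(C)C)c2c1[C@@H](c1ccc(Oc3ccccc3)cc1)S[C@@H](C)C(=O)N2` gives 174%. Going by the values given here, these two compounds share one core and differ only in the group on the aromatic carbon: the change is a number 56 percentage points higher from compound 1 to compound 2 (beyond the scatter), so compound 2 stands highest of the two numbers, with compound 1 as its only neighbour, well apart from it. Compound 3 `CCc1ccccc1-n1nc(C)c2c1NC(=O)[C@H](C)S[C@@H]2c1ccc(Oc2ccccc2)cc1` comes next; it differs from compound 2 by hydrogen in place of methyl on a saturated chain carbon bound to an aromatic carbon and a saturated chain carbon. Among the compounds with values here, this is a partial reversal of the single step seen so far, since the isopropyl of compound 2 shrinks to an ethyl rather than all the way back to the methyl of compound 1. The expected step is therefore a drop, but a smaller one than the gain from compound 1 to compound 2, and the change from compound 2 to compound 3 is estimated as a number 29 percentage points lower from compound 2 to compound 3 (beyond the scatter). Compound 3 is thus expected to give about 145%, within a range from 115% to 175%.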

Compound 3, largest response reached (reported as efficacy), in percent of the reference or control that the assay uses: 190%
The estimate for compound 3 lay 45 percentage points below the measured number; measured number outside the range, above it.
By their numbers in this assay, from the lowest: compound 1; then compound 2; then compound 3.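

In this assay, the response does not simply rise as this group grows. Taking one methyl off the isopropyl to leave the ethyl gives a number 16 percentage points higher from compound 2 to compound 3 (beyond the scatter), while adding one methyl to the small methyl group of compound 1 to make the same ethyl gives a number 72 percentage points higher from compound 1 to compound 3 (beyond the scatter), so across these three compounds the order runs methyl, then isopropyl, then ethyl, with the ethyl on top and the largest group in the middle. Nothing measured here explains why the ethyl gives the largest response.

Going by these compounds, whether a straight propyl chain, a cyclopropyl ring or a methoxy group in this place would match or pass the ethyl stays open. Also open, on these data alone, is whether the ethyl keeps its lead when other parts of the shared core change.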